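One fluorine moved, little change expected

A few compounds are considered here, and "the series" means these few. Any claim that something is new, unique, unknown or untested is made for them only; others in the source may bear on it.

Among the compounds with values here, compound 1 `Fc1cccc(NC(=S)N/N=C/c2ccc3ccccc3n2)c1` is the only one of three compounds that gives a number in a functional assay on HL-60 cells (Homo sapiens) for antiproliferative activity, read by sulforhodamine B assay, with a stated time of 72 h; on this read-out higher numbers stand for weaker inhibition and lower numbers for stronger inhibition: in this assay compound 1 gives 43800 nM. Compound 2 `NC(=S)N/N=C/c1cc2ccccc2s1` reaches only a limit of the assay, recorded as > 100000 nM. Compound 3 `Cc1csc2sc(/C=N/NC(N)=S)c(C)c12` likewise reaches only a limit, recorded as > 100000 nM. Compound 1 therefore stands alone with a measured figure, while the other two values sit at the limit of > 100000 nM in this assay, at which 2 of the 3 values shown sit.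

Compound 4 `Fc1ccccc1NC(=S)N/N=C/c1ccc2ccccc2n1` has not yet been measured. It differs from compound 1 in a single place: 2-fluorophenyl in place of 3-fluorophenyl on an amide-type nitrogen. Within the data shown here, no measured pair of compounds differs in just one place, so no step of this kind has been seen directly. Moving the fluorine within the same ring while keeping every atom is expected to produce no step beyond the usual scatter, so the step from compound 1 to compound 4 is estimated as a 1.0-fold higher number from compound 1 to compound 4 (0.01 log units; within the scatter). Compound 4 is accordingly expected to give about 45000 nM, with a likely range from 15000 nM to 100000 nM.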

Compound 4, half-maximal inhibitory concentration: > 100000 nM
Compound 4: no number, only a limit (the forecaster's own chance of this, stated with the estimate: 25%); middle value at least 2.2-fold (0.34 log units) away from the limit.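

Within the data shown here, replacing 3-fluorophenyl with 2-fluorophenyl on the amide-type nitrogen, with the same atoms joined differently, gives an at least 2.2-fold higher number from compound 1 to compound 4 (0.35 log units; beyond the scatter) in this assay and so leaves compound 1 as the only compound here with a measured number. Among these compounds, this is the first direct comparison of compounds that differ in one place, and it shows that where the fluorine sits on this ring can matter, even though no atom is gained or lost. The true size of the step cannot be read because compound 4 gives only a limit, not a number: the limit of > 100000 nM in this assay, at which 3 of the 4 values shown sit.

From the compounds shown here alone, it remains open whether a chlorine atom or a methoxy group in place of the fluorine would give a measured number. Also open, going by these compounds, is whether an amine on this ring would keep or lose the activity of compound 1.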